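From Compound 1 to Compound 4: an Expected Small Step

The source may report more compounds than this note shows. Statements on the series, on what has been measured and on what is new or still open speak of the compounds shown alone.

Compound 1 `O=C(/C=C1\CCc2ccc(F)cc21)NCC1CC1` is tested in a functional assay on the whole organism with Rattus norvegicus as the target, at a dose of 20 mg/kg by the oral route (a higher number here means more inhibition at the dose given (going by the name of the read-out), a lower number less inhibition), where compound 1 gives 0%. Compound 2 `CNC(=O)/C=C1\CCc2ccc(Cl)cc21` gives 0% in this assay, the same figure at the digits shown, so the two are level and together the lowest of the three numbers. Compound 3 `COc1ccc2c(c1)CC/C2=C\C(N)=O` gives 18%, a higher figure whose gap to compound 1 lies beyond the usual scatter. Compound 4 `CCN(C)C(=O)/C=C1\CCc2ccc(F)cc21` has not yet been measured. It differs from compound 1 in one place: ethyl(methyl)amino in place of (cyclopropylmethyl)amino on a carbonyl carbon. Among the compounds with values here, no pair of measured compounds differs by such a change, so nothing here shows its effect. Compound 4 is expected to stay close to compound 1, with an expected a number 3 percentage points higher from compound 1 to compound 4 (within the scatter) that is not beyond the scatter. Compound 4 is therefore estimated at 3%, within 0% to 12%.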

Compound 4, a percentage reported as inhibition, in the whole organism at one dose (the size of the read-out at that dose, not a potency): 20%
The estimate for compound 4 lay 17 percentage points below the measured number, and the stated range ends below it.
By their numbers in this assay, from the lowest: compounds 1 and 2 (each within the scatter of the next); then compounds 3 and 4 (each within the scatter of the next).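

On the carbonyl carbon, the group attached clearly matters in this assay: ethyl(methyl)amino in place of (cyclopropylmethyl)amino gives a number 20 percentage points higher from compound 1 to compound 4 (beyond the scatter). This one change removes the three-membered ring and the hydrogen-bond donor together, so the step cannot show which of the two counts. Nothing available explains the step.

Still open, going by these compounds, is how a dimethylamino group, a diethylamino group or a morpholine ring on the same carbonyl carbon would compare. It is also unknown whether the step would recur on a core carrying chlorine instead of fluorine.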